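A change of configuration alone in compound 4

This account rests on a few compounds, and the source may have more. Where it says the series, first, only, none or still open, it means among the compounds named here.

Measured in an ADME assay on liver for metabolic stability, with Liver microsome (Rattus norvegicus) as the target, read by LC-MS, using microsomes, with a stated time of 5 h; a lower number here means slower removal, a higher number faster removal of the compound:
- compound 1 `O[C@H](c1ccccn1)[C@]1(c2cccc(OC(F)(F)F)c2)C[C@H](O)C1`: 117 mL/min/kg
- compound 2 `C[C@]1(O)C[C@](c2cccc(C(F)(F)F)c2)([C@H](O)c2ccccn2)C1`: 66.7 mL/min/kg
- compound 3 `O[C@H](c1ccccn1)[C@]1(c2cccc(C(F)(F)F)c2)C[C@H](O)C1`: 183 mL/min/kg

Two measured steps place compound 3 at the high end of these numbers. The first, with trifluoromethyl in place of trifluoromethoxy on an aromatic carbon, is a 1.6-fold higher number from compound 1 to compound 3 (0.19 log units; within the scatter). The second, with hydrogen in place of methyl on a saturated ring carbon, is a 2.7-fold higher number from compound 2 to compound 3 (0.44 log units; beyond the scatter).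

The next structure is compound 4 `O[C@H](c1ccccn1)[C@]1(c2cccc(C(F)(F)F)c2)C[C@@H](O)C1`, and its relation to compound 3 is this: the two compounds have the same atoms and bonds and differ only in configuration as drawn: 2 of 3 stereo elements differ; a stereocentre at a saturated ring carbon is drawn s in compound 3 and r in compound 4; a stereocentre at a saturated ring carbon is drawn R in compound 3 and S in compound 4.

Among the compounds with values here, no measured step is a change of configuration alone, so the data hold no direct guide. The aromatic step says little here. Within the data shown here, the closest evidence is the modest 2.7-fold higher number from compound 2 to compound 3 (0.44 log units; beyond the scatter), the only measured change on a saturated ring carbon, and it shows that this assay can respond to a change at such a carbon. It gives no direction for a change of configuration. Compound 3 already reads 183 mL/min/kg, the top of this small range, so a slight fall is thought likelier than a rise. The expected step is a 1.3-fold lower number from compound 3 to compound 4 (0.12 log units; within the scatter), and no shift beyond the scatter is expected. For compound 4 the estimated clearance is 140 mL/min/kg, with an expected range of 70 mL/min/kg to 260 mL/min/kg.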

Compound 4, clearance: 100 mL/min/kg
Estimate against measurement, compound 4: 1.4-fold (0.15 log units) above; low and high end bracket the measured number.
By their numbers in this assay, from the lowest: compounds 2, 4, 1 and 3 (each within the scatter of the next, the first and the last beyond it).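

Within the data shown here, compound 4 gives the first measured reading of a change of configuration alone, and in this assay the result is a 1.8-fold lower number from compound 3 to compound 4 (0.26 log units; within the scatter), so the redrawing of these two stereocentres at saturated ring carbons does not separate the pair beyond the usual scatter of repeats. Any difference in this reading can be traced to one source alone, and no swap of a group blurs the comparison: the fact that compounds 3 and 4 differ only in the configuration as drawn. The earlier compounds shown here showed only that this assay can respond to a change on a saturated ring carbon, through a 2.7-fold higher number from compound 2 to compound 3 (0.44 log units; beyond the scatter), whereas this pair shows that at this position, with hydrogen on the ring carbon and trifluoromethyl on the aromatic carbon, configuration as drawn gives no step beyond the scatter.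

From the compounds shown here alone, both stereocentres differ together in compound 4, so what each contributes alone remains unknown, as does whether the same change would read alike with the methyl of compound 2 or the trifluoromethoxy of compound 1 in place. Going by these compounds, how this assay would respond to an amine or a carboxylic acid on the saturated ring carbon also stays open.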